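Extending the chain and swapping the para group

A few compounds are considered here, and "the series" means these few. Any claim that something is new, unique, unknown or untested is made for them only; others in the source may bear on it.

Three anilides of short chloroalkyl acids have been measured in a functional assay on M21 cells (Homo sapiens) for antiproliferative activity, with a stated time of 48 h; on this read-out lower numbers stand for stronger inhibition and higher numbers for weaker inhibition. Compound 1, `O=C(CCCl)Nc1ccc(I)cc1`, gives 20000 nM. Compound 2, `CC(C)(C)c1ccc(NC(=O)CCCl)cc1`, differs from it by tert-butyl in place of iodo on an aromatic carbon and gives 74000 nM; this is a 3.7-fold higher number from compound 1 to compound 2 (0.57 log units; beyond the scatter). Compound 3, `O=C(CCCCl)Nc1ccc(I)cc1`, differs from compound 1 by chloromethyl in place of chloro on a saturated chain carbon, two bonds along the chain from a carbonyl carbon. For compound 3 this assay reports only a limit, > 100000 nM, which is the upper edge the assay can read (the limit of > 100000 nM in this assay, at which 1 of the 3 values shown sits). From compound 1 to compound 3 the step is therefore an at least 5.0-fold higher number from compound 1 to compound 3 (0.69 log units; beyond the scatter).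

Compound 4, `CC(C)(C)c1ccc(NC(=O)CCCCl)cc1`, is not yet measured. It differs from compound 3 by tert-butyl in place of iodo on an aromatic carbon. Among the compounds with values here, this is the same kind of change as the one from compound 1 to compound 2, though not the same: in compound 1 the aromatic carbon is para to a group of 6 heavy atoms, in compound 3 para to a group of 7 heavy atoms. The measured step for this change, a 3.7-fold higher number from compound 1 to compound 2 (0.57 log units; beyond the scatter), weakened inhibition. Since compound 3 already sits at the limit of this assay, any further weakening would keep compound 4 beyond that limit, so the expected step from compound 3 to compound 4 is written as a step that the limit leaves unreadable from compound 3 to compound 4. Compound 4 is expected to give about 300000 nM in this assay, most likely reported only as a limit, with a range of 100000 nM to 1000000 nM.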

Compound 4, half-maximal inhibitory concentration: > 100000 nM
Compound 4 gave a limit, no number; the forecaster's own chance of this, stated with the estimate: 90%; the middle value is on the limit's open side.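

In this assay compound 4 gives > 100000 nM, which is a limit and not a number, so the step between compound 3 and compound 4 cannot be read. With chloromethyl in place of chloro on the tert-butyl core, the reading is an at least 1.3-fold higher number from compound 2 to compound 4 (0.13 log units; that floor lies within the scatter), so this core on its own does not establish a real change, although the limit leaves room for one. On the iodo core the same change clearly weakened inhibition, so the result neither confirms nor rules out that the change carries over with a similar size: the same change on two cores in this assay, an at least 5.0-fold higher number (0.69 log units; beyond the scatter) from compound 1 to compound 3 and an at least 1.3-fold higher number (0.13 log units; that floor lies within the scatter) from compound 2 to compound 4; the limit leaves it open whether they differ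

Going by these compounds, how much weaker any compound at the limit truly is remains unknown, and so does any ranking among such compounds: the limit of > 100000 nM in this assay, at which 2 of the 4 values shown sit. Also open is whether an amine or a carboxylic acid in place of iodo or tert-butyl, or bromo in place of chloro on the chain, would give a readable number in this assay.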